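Urea series: cytotoxicity limits and a demethoxylated analogue

A few compounds are considered here, and "the series" means these few. Any claim that something is new, unique, unknown or untested is made for them only; others in the source may bear on it.

Compound 1 `COc1ccc(NC(=O)Nc2cc(C)nc3ccccc23)cc1OC` is the reference point of this set. In an ADME assay on HEK293 cells (Homo sapiens) for cytotoxicity, with a stated time of 72 h (on this read-out lower numbers stand for an effect already at smaller amounts and higher numbers for an effect only at larger amounts of compound), compound 1 gives > 25000 nM, which is a limit of the assay and not a number. Compound 2 `Cc1cc(NC(=O)Nc2cnc3ccccc3c2)c2ccccc2n1` and compound 3 `COc1ccccc1NC(=O)Nc1cc(C)nc2ccccc12` were run in the same test. In this assay compound 2 gives > 25000 nM, again only a limit. In this assay compound 3 gives > 25000 nM, also a limit. Compound 1 therefore stands where every value shown stands: the limit of > 25000 nM in this assay, at which 3 of the 3 values shown sit. Within the data shown here, no step between measured compounds can be drawn, since none of the three differs from another in a single place, and none of them carries a number at all.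

Compound 4 `COc1ccc(NC(=O)Nc2cc(C)nc3ccccc23)cc1` is not yet measured. It differs from compound 1 by hydrogen in place of methoxy on an aromatic carbon. With all three measured compounds sitting at the limit, nothing measured indicates how large this change could be. The expectation is that compound 4 also remains at the limit, so no step beyond the scatter is expected. For compound 4 the estimate in this assay is 40000 nM, in the range 20000 nM to 100000 nM. The expected step that the limit leaves unreadable from compound 1 to compound 4 is thus within the scatter, and a further limit rather than a number is the most likely outcome.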

Compound 4, half-maximal effective concentration: > 25000 nM
Compound 4: no number, only a limit; the forecaster's own chance of this, stated with the estimate: 85%; the middle value lies beyond the limit too.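

No step can be read between compound 1 and compound 4 in this assay, since both sit at a limit and neither gives a number: the limit of > 25000 nM in this assay, at which 4 of the 4 values shown sit.

The compounds shown leave open where any of them would reach a half-maximal effect in this assay, and whether hydrogen in place of methoxy changes that read-out at all.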